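Benzyloxy for butylamino on the shared core

A few compounds are considered here, and "the series" means these few. Any claim that something is new, unique, unknown or untested is made for them only; others in the source may bear on it.

Three compounds of the series have been run in an ADME assay on MOLT-3 cells (Homo sapiens) for cytotoxicity, with a stated time of 7 days; on this read-out higher numbers stand for lower toxicity in this test and lower numbers for higher toxicity in this test. Compound 1 `CCCCCOc1nc(N)nc2c1ncn2/C=C1/CC1(CO)CO` gives > 20000 nM, a limit of the test rather than a number. Compound 2 `CCCCNc1nc(N)nc2c1ncn2/C=C1/CC1(CO)CO` gives > 20000 nM, again a limit. Compound 3 `Nc1nc2c(ncn2/C=C2/CC2(CO)CO)c(=O)[nH]1` gives > 20000 nM, also a limit. Going by the values given here, the one step measured between neighbours, a step that the two limits leave unreadable from compound 1 to compound 2, cannot be read because of the limit of > 20000 nM in this assay, at which 3 of the 3 values shown sit. Compound 2 thus stands only at a limit in this assay, and so do the other two.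

Compound 4 `Nc1nc(OCc2ccccc2)c2ncn(/C=C3/CC3(CO)CO)c2n1` is the next compound to be measured in this assay. It differs from compound 2 by benzyloxy in place of butylamino on an aromatic carbon. Among the compounds with values here, no readable measured step bears on this change; the only step known, from compound 1 to compound 2, is unreadable. The expected step is a step that the limit leaves unreadable from compound 2 to compound 4, nothing beyond scatter. This rests on compound 2 sitting at the limit and on (the limit of > 20000 nM in this assay, at which 3 of the 3 values shown sit). For compound 4 the estimated value in this assay is 30000 nM, within 10000 nM to 100000 nM, most probably reported again only as a limit.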

Compound 4, half-maximal cytotoxic concentration: > 20000 nM
Compound 4: no number, only a limit; the forecaster's own chance of this, stated with the estimate: 80%; the middle value does not contradict the limit.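

Neither step to compound 4, from compound 2 or from compound 1, can be read in this assay: the limit of > 20000 nM in this assay, at which 4 of the 4 values shown sit.

The compounds shown leave open whether any substituent on this aromatic carbon of the shared core changes the read-out, as none gives a number.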